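This account rests on a few compounds, and the source may have more. Where it says the series, first, only, none or still open, it means among the compounds named here.

Measured compounds:
Compound 1 `Nc1ccc(S(=O)(=O)N2CCN(c3ncc(C(O)(C(F)(F)F)C(F)(F)F)cc3-c3ccoc3)CC2)cn1`; in an ADME assay (liver) for metabolic stability, with Liver microsome (Rattus norvegicus) as the target, using microsomes and NADPH, with a stated time of 30 min, tested at 1 uM (on this read-out higher numbers stand for fast clearance and lower numbers for slow clearance), compound 1 gives 57 mL.min-1.g-1.
Compound 2 `CS(=O)(=O)Nc1cccc(-c2cc(C(O)(C(F)(F)F)C(F)(F)F)cnc2N2CCN(S(=O)(=O)c3ccc(N)nc3)CC2)c1`; in this assay compound 2 gives 81 mL.min-1.g-1.

Among the compounds with values here, of these two numbers, compound 2 holds the higher one, with compound 1 as its only neighbour; the step of a 1.4-fold higher number from compound 1 to compound 2 (0.15 log units; within the scatter) is within the scatter, so the two compounds cannot be told apart on this read-out.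

Compound 3 `Nc1ccc(S(=O)(=O)N2CCN(c3ncc(C(O)(C(F)(F)F)C(F)(F)F)cc3-c3cc4ccccc4[nH]3)CC2)cn1` has not yet been measured in this assay. It differs from compound 2 in one place: 1H-indol-2-yl in place of 3-(methanesulfonamido)phenyl on an aromatic carbon.

Within the data shown here, only one measured step speaks to this change, the exchange of the group on the same aromatic carbon that separates compound 1 from compound 2, a 1.4-fold higher number from compound 1 to compound 2 (0.15 log units; within the scatter). That step stayed within the scatter. With a single comparison of this kind and no data for the entering group, the account rests on that step alone, and no movement beyond the scatter is expected for a 1.0-fold lower number from compound 2 to compound 3 (0.01 log units; within the scatter). Compound 3 is therefore estimated at 80 mL.min-1.g-1 in this assay, with an expected range from 40 mL.min-1.g-1 to 170 mL.min-1.g-1.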

Compound 3, intrinsic clearance in microsomes: 146 mL.min-1.g-1
Compound 3: middle estimate off by 1.8-fold (0.26 log units), on the low side; the measured number falls inside the stated range.
By their numbers in this assay, from the lowest: compounds 1, 2 and 3 (each within the scatter of the next, the first and the last beyond it).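

Across the three groups seen on this aromatic carbon, ortho to a large group and two atoms from the ring nitrogen, compound 3 supplies the first step in this assay that clears the scatter: a 2.6-fold higher number from compound 1 to compound 3 (0.41 log units; beyond the scatter). The earlier pair had shown no separation, so the read-out had not yet responded to any exchange at this position; now the 1H-indol-2-yl and furan-3-yl groups can be told apart, though only modestly. The other new step, a 1.8-fold higher number from compound 2 to compound 3 (0.26 log units; within the scatter), stays within the scatter, so 1H-indol-2-yl and 3-(methanesulfonamido)phenyl cannot be separated, and the three compounds form a chain in which only the two ends differ.

On these data alone, whether an amine, a carboxylic acid or a short alkyl chain on this carbon would take the number clearly away from the range these three compounds span remains open, as does whether a number well below that of compound 1 can be reached here at all. Nothing on hand bears on why the number shifts with this exchange.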